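This account rests on a few compounds, and the source may have more. Where it says the series, first, only, none or still open, it means among the compounds named here.

Compound 1 `COc1ccc(/C=C/C(=O)C(=Cc2ccc(O)c(F)c2)C(=O)/C=C/c2ccc(OC)cc2OC)c(OC)c1` and compound 2 `COc1ccc(/C=C/C(=O)C(=Cc2cc(Br)c(O)c(OC)c2)C(=O)/C=C/c2ccc(OC)cc2OC)c(OC)c1` share one core. In a functional assay on SW480 cells (Homo sapiens) for antiproliferative activity, read by sulforhodamine B assay, with a stated time of 48 h (a higher number here means a weaker inhibitor, a lower number a stronger inhibitor), compound 1 gives 3350 nM, and compound 2 gives 1480 nM. The change between them is 3-bromo-4-hydroxy-5-methoxyphenyl in place of 3-fluoro-4-hydroxyphenyl on a double-bonded chain carbon bound to a double-bonded chain carbon, and it brought a 2.3-fold lower number from compound 1 to compound 2 (0.35 log units; beyond the scatter). Compound 3 `COc1cc(OC)c(/C=C/C(=O)C(=Cc2ccc(O)c(F)c2)C(=O)/C=C/c2c(OC)cc(OC)cc2OC)c(OC)c1` is built on a different core; the difference between the two cores is not broken down here. In this assay compound 3 gives 1950 nM, a number that sits within the usual scatter of both compound 1 and compound 2. Compound 4 `COc1cc(OC)c(/C=C/C(=O)C(=Cc2cc(Br)c(O)c(OC)c2)C(=O)/C=C/c2c(OC)cc(OC)cc2OC)c(OC)c1` arises from compound 3 by the same change, (3-bromo-4-hydroxy-5-methoxyphenyl in place of 3-fluoro-4-hydroxyphenyl on a double-bonded chain carbon bound to a double-bonded chain carbon), at the same place. The same change once gave a 2.3-fold lower number from compound 1 to compound 2 (0.35 log units; beyond the scatter), and on that a comparable step is expected here. Compound 4 is thus expected to show a 2.2-fold lower number from compound 3 to compound 4 (0.34 log units; beyond the scatter). The estimate for compound 4 is 900 nM, between 400 nM and 2000 nM.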

Compound 4, half-maximal inhibitory concentration: 1450 nM
For compound 4 the middle estimate is 1.6-fold (0.21 log units) below the measured one; low and high end bracket the measured number.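

On the second core the change gave, in this assay, a 1.3-fold lower number from compound 3 to compound 4 (0.13 log units; within the scatter), and set beside the earlier step the two do not differ: the same change on two cores in this assay, a 2.3-fold lower number (0.35 log units; beyond the scatter) from compound 1 to compound 2 and a 1.3-fold lower number (0.13 log units; within the scatter) from compound 3 to compound 4, 1.7-fold (0.23 log units) apart, within the scatter of two such steps. The result is therefore consistent with the change carrying over from one core to the other, with no sign that the core alters it. It does not show a firm gain on the second core, where the step alone stays within the scatter, and two pairs can neither fix the size of the change nor show that it would hold on further cores.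

The compounds shown leave open which part of the entering group, the bromine or the methoxy, goes with the step on the core of compound 1. They also leave open how an amine or a carboxylic acid in place of the bromine would fare.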